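Substitution at the pyrazole nitrogen: compound 3 to compound 4

The compounds below may be only part of what the source reports. "The series", "measured", "known", "first", "only" and "open" are said of these compounds alone.

Measured so far in an assay on isolated protein for inhibition of Discoidin domain-containing receptor 2 (Homo sapiens), read by ELISA, with a stated time of 60 min; on this read-out higher numbers stand for weaker inhibition and lower numbers for stronger inhibition:
compound 1 `Cc1ccc(C(=O)Nc2ccc(CN3CCN(C)CC3)cc2)cc1-c1ccc2cn[nH]c2c1` gives 6.7 nM
compound 2 `Cc1ccc(C(=O)Nc2cccc(C(F)(F)F)c2)cc1-c1ccc2c(-c3ccc(N4CCN(C)CC4)cc3)n[nH]c2c1` gives 8.8 nM
compound 3 `Cc1ccc(C(=O)Nc2cccc(C(F)(F)F)c2)cc1-c1ccc2c(-c3cn[nH]c3)n[nH]c2c1` gives 55.6 nM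

Compound 3 stands at the highest number of the three, that is the weakest inhibition shown. Its nearest neighbour is compound 2, whose number is lower by a gap beyond the scatter; compound 1 sits further off again, also beyond the scatter. Within the data shown here, compounds 2 and 3 share the whole amide portion and differ only in the group attached to the shared core, so the values indicate that a larger substituent at that point goes with a lower number, but no step between them is counted here.

Compound 4 `Cc1ccc(C(=O)Nc2cccc(C(F)(F)F)c2)cc1-c1ccc2c(-c3cnn(CC(C)O)c3)n[nH]c2c1` is the next member. The change from compound 3 is 2-hydroxypropyl in place of hydrogen on an aromatic nitrogen.

Among the measured compounds shown here, no measured pair follows this exact change. Given that compound 2, carrying a larger group at the same point of the core, gives 8.8 nM, a modest move toward lower numbers is expected for compound 4, estimated as a 1.9-fold lower number from compound 3 to compound 4 (0.27 log units; within the scatter). Compound 4 is therefore expected at about 30 nM, within a range from 10 nM to 90 nM.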

Compound 4, half-maximal inhibitory concentration: 3.7 nM
Compound 4: middle estimate off by 8.1-fold (0.91 log units), on the high side, outside the stated range (below it).
By their numbers in this assay, from the lowest: compounds 4, 1 and 2 (each within the scatter of the next, the first and the last beyond it); then compound 3.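

In this assay the change to 1-(2-hydroxypropyl)-1H-pyrazol-4-yl gives a 15-fold lower number from compound 3 to compound 4 (1.18 log units; beyond the scatter) and so shows that the aromatic nitrogen of the five-membered ring is a sensitive point, where a small chain without a ring is enough for a large move toward stronger inhibition. The earlier compounds shown here could not show this, as they held no pair differing at this nitrogen, and their comparison of compound 2 with compound 3 suggested that a larger group on the shared core goes with a lower number. Compound 2 gives 8.8 nM and compound 4 gives 3.7 nM, so compound 4 now has the lower number by a gap beyond the scatter with a far smaller added group, and no measurement shown here explains the gain.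

Going by these compounds, what remains open is whether the hydroxyl group or the carbon chain carries the step, which a plain propyl chain or a methyl group on the same nitrogen would separate. On these data alone, how far this nitrogen tolerates other kinds of group also stays unknown, for example a 2-aminoethyl chain, a carboxylic acid or a longer hydroxyalkyl chain.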